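The source may report more compounds than this note shows. Statements on the series, on what has been measured and on what is new or still open speak of the compounds shown alone.

The measured compounds, each in a functional assay on HeLa cells (Homo sapiens) for cytotoxicity, read by sulforhodamine B assay; on this read-out lower numbers stand for stronger inhibition and higher numbers for weaker inhibition:

Compound 1, `Cc1ccc(S(=O)(=O)NC(C2=CC(=O)c3c(O)ccc(O)c3C2=O)C(C)C)cc1`, gives 4850 nM.
Compound 2, `CC(C)C(NS(=O)(=O)c1ccc(F)cc1)C1=CC(=O)c2c(O)ccc(O)c2C1=O`, gives 6650 nM.
Compound 3, `Cc1ccc(S(=O)(=O)NC(C)C2=CC(=O)c3c(O)ccc(O)c3C2=O)cc1`, gives 5340 nM.

All three share the same core and differ only in the group on the aromatic ring of the sulfonamide or in the chain next to the sulfonamide nitrogen. Compound 3 stands second highest of the three numbers, yet its neighbours sit close: the step of a 1.1-fold higher number from compound 1 to compound 3 (0.04 log units; within the scatter), and the step of a 1.4-fold higher number from compound 1 to compound 2 (0.14 log units; within the scatter). Nothing among the three rises above the scatter, so none of them can be called stronger or weaker than another.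

Compound 4, `CC(=O)c1ccc(S(=O)(=O)NC(C)C2=CC(=O)c3c(O)ccc(O)c3C2=O)cc1`, has not yet been measured. It differs from compound 3 in one place: acetyl in place of methyl on an aromatic carbon.

For the measured compounds named here, the step that bears most on this change is the one from compound 1 to compound 2, which also swaps the group on the aromatic ring; it gave a 1.4-fold higher number from compound 1 to compound 2 (0.14 log units; within the scatter). The step from compound 1 to compound 3 alters the chain instead and says little here. Going by the values given here, with only one comparable step, and that one flat, compound 4 is expected to show a 1.0-fold higher number from compound 3 to compound 4 (0.01 log units; within the scatter), with no shift beyond the scatter. The estimate for compound 4 is therefore 5500 nM, within a range of 2500 nM to 12000 nM.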

Compound 4, half-maximal inhibitory concentration: 5760 nM
The estimate for compound 4 lay 1.0-fold (0.02 log units) below the measured number, within the range that was stated.
By their numbers in this assay, from the lowest: compounds 1, 3, 4 and 2 (each within the scatter of the next).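

Putting acetyl in place of methyl on this aromatic carbon, para to a large group, adds heavy atoms, a double bond and a hydrogen-bond acceptor, yet in this assay it gives a 1.1-fold higher number from compound 3 to compound 4 (0.03 log units; within the scatter). The earlier compounds had shown only the swap of methyl for fluoro at this place, with isopropyl on the chain, as a 1.4-fold higher number from compound 1 to compound 2 (0.14 log units; within the scatter); this new step adds a larger group, with methyl on the chain, and again the number stays within the scatter, so in these two pairs neither replacement separates from methyl in this assay. For the compounds shown here, nothing available explains why these changes leave the number flat, so the result records only that the number holds and gives no reason for it.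

Still open, on these data alone, is whether an amine or a carboxylic acid on this aromatic carbon, groups that differ from methyl, fluoro and acetyl, would move the number beyond the scatter. Also open, as far as these compounds go, is whether a longer chain in place of the isopropyl or methyl on the saturated carbon would shift it, or would change how the aromatic group behaves.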